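This account rests on a few compounds, and the source may have more. Where it says the series, first, only, none or still open, it means among the compounds named here.

Measured compounds:

Compound 1 `Cc1ccccc1-n1nncc1CN1C(=O)C2(C(C#N)=C(N)Oc3c2c2nc4ccccc4nc2c2ccccc32)c2ccccc21` — in a functional assay on HepG2 cells (Homo sapiens) for antiproliferative activity, read by MTT assay, with a stated time of 48 h (on this read-out higher numbers stand for weaker inhibition and lower numbers for stronger inhibition), compound 1 gives > 50000 nM, which is a limit of the assay and not a number.

Compound 2 `N#CC1=C(N)Oc2c(c3nc4ccccc4nc3c3ccccc23)C12C(=O)N(Cc1cnnn1-c1ccccc1Cl)c1ccccc12` — in this assay compound 2 gives > 50000 nM, likewise a limit of the assay and not a number.

Compound 2 therefore stands at the limit, with no number to rank it against anything. Among the measured compounds shown here, the one measured step, a step that the two limits leave unreadable from compound 1 to compound 2, is chloro in place of methyl on an aromatic carbon, and its size cannot be read, because the limit of > 50000 nM in this assay, at which 2 of the 2 values shown sit, holds both values shown. The unmeasured compound 3 `N#CC1=C(N)Oc2c(c3nc4ccccc4nc3c3ccccc23)C12C(=O)N(Cc1cnnn1-c1ccccc1Br)c1ccccc12` differs from compound 2 by bromo in place of chloro on an aromatic carbon. For the measured compounds named here, the only step that bears on it is the unreadable one from compound 1 to compound 2, and the present change is of the same kind, a halogen swap at the same aromatic carbon, so no step beyond the scatter is expected, and it is expected that compound 3 again returns a limit rather than a number. The estimate for compound 3 in this assay is 60000 nM, expected between 20000 nM and 200000 nM, which means an expected step that the limit leaves unreadable from compound 2 to compound 3.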

Compound 3, half-maximal inhibitory concentration: > 50000 nM
Compound 3: no number, only a limit; the forecaster's own chance of this, stated with the estimate: 85%; the middle value does not contradict the limit.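

In this assay compound 3 gives > 50000 nM, which is a limit of the assay and not a number. The steps linking compound 1, compound 2 and compound 3 therefore cannot be read: the limit of > 50000 nM in this assay, at which 3 of the 3 values shown sit. The compounds shown leave open whether methyl, chloro or bromo on this aromatic carbon makes any difference to the read-out.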